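Swapping a Chloro for a Hydroxy on the Benzylidene Ring

A few compounds are considered here, and "the series" means these few. Any claim that something is new, unique, unknown or untested is made for them only; others in the source may bear on it.

Measured compounds:
- compound 1, `Cn1nnnc1SCC(=O)N/N=C/c1ccccc1`: 9700000 nM
- compound 2, `CN(C)c1ccc(/C=N/NC(=O)CSc2nnnn2C)cc1`: 316000 nM
- compound 3, `Cn1nnnc1SCC(=O)N/N=C/c1cccc(Cl)c1`: 7500000 nM

Three compounds share one core and differ only in a substituent on the six-membered carbon ring. In an ADME assay on NIH3T3 cells (Mus musculus) for cytotoxicity, read by XTT assay, with a stated time of 24 h (on this read-out lower numbers stand for stronger inhibition and higher numbers for weaker inhibition), compound 3 gives 7500000 nM, the second highest of the three numbers; it sits close to compound 1 and far from compound 2, which gives 316000 nM.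

Compound 4, `Cn1nnnc1SCC(=O)N/N=C/c1cccc(O)c1`, carries hydroxy in place of chloro on an aromatic carbon. The change sits on an aromatic carbon of a six-membered aromatic ring of carbon only, meta to a large group.

Within the data shown here, no measured step exchanges chloro for hydroxy. The nearest guide is a 1.3-fold lower number from compound 1 to compound 3 (0.11 log units; within the scatter), showing that adding chloro changed little. The only large move, a 31-fold lower number from compound 1 to compound 2 (1.49 log units; beyond the scatter), came from dimethylamino, a group not involved here. A hydroxy is therefore expected to give at most a small step, and compound 4 is estimated at 6000000 nM (range 1500000 nM to 20000000 nM), meaning an expected step of a 1.3-fold lower number from compound 3 to compound 4 (0.10 log units; within the scatter).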

Compound 4, half-maximal inhibitory concentration: 3160000 nM
Compound 4: middle estimate off by 1.9-fold (0.28 log units), on the high side, and the stated range covers the measured number.
By their numbers in this assay, from the lowest: compound 2; then compound 4; then compounds 3 and 1 (each within the scatter of the next).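

Hydroxy in place of chloro gives a 2.4-fold lower number from compound 3 to compound 4 (0.38 log units; beyond the scatter), and hydroxy in place of hydrogen gives a 3.1-fold lower number from compound 1 to compound 4 (0.49 log units; beyond the scatter). In this assay, this aromatic carbon, meta to a large group, therefore does not treat every small substituent alike: chloro left the number within the scatter of compound 1, which carries hydrogen there, whereas hydroxy moves it beyond the scatter by a modest step. No measurement shown explains why these two groups differ.

Hydroxy brings a hydrogen-bond donor and a hydrogen-bond acceptor that chloro lacks, but the compounds shown cannot tell whether either one matters to this result. From the compounds shown here alone, how a methoxy or an amine on this same carbon would compare with hydroxy remains open.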